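The compounds below may be only part of what the source reports. "The series", "measured", "known", "first", "only" and "open" are said of these compounds alone.

Compound 2 `CN1CCN(CC(=O)Nc2ccc(-c3nc4cc(C(F)(F)F)ccc4n3C)cc2)CC1` carries a ((4-methylpiperazin-1-yl)methyl)carbonyl group on an amine nitrogen attached to an aromatic ring. In an ADME assay on Vero cells (Chlorocebus sabaeus) for cytotoxicity (on this read-out lower numbers stand for higher toxicity in this test and higher numbers for lower toxicity in this test), compound 2 gives > 100000 nM, and this is a limit of the assay rather than a number. Among the compounds with values here, it is the one value among the three that sits at the limit of > 100000 nM in this assay, at which 1 of the 3 values shown sits. Compound 4 `Cn1c(-c2ccc(N)cc2)nc2cc(C(F)(F)F)ccc21` differs from compound 2 by hydrogen in place of ((4-methylpiperazin-1-yl)methyl)carbonyl on a nitrogen on an aromatic ring.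

Within the data shown here, only one measured step touches this part of the molecule: an at least 3.3-fold lower number from compound 2 to compound 3 (0.52 log units; beyond the scatter), where compound 3 `Cn1c(-c2ccc(NC(=O)CN3CCN(c4ccccc4)CC3)cc2)nc2cc(C(F)(F)F)ccc21` gives 30000 nM in this assay. That step alters the far end of the group rather than removing it, so it bears only loosely on compound 4. Compound 1 `COc1ccc(-c2nc3cc(C(F)(F)F)ccc3[nH]2)c(N)c1`, which also bears a free amino group on an aromatic ring though with a different core, gives 50000 nM in this assay. Taken together, these points give no strong reason to expect a step beyond the scatter in either direction, though the removal of the whole group is a larger change than any measured here.

Compound 4 is therefore expected to give about 60000 nM in this assay, within a range of 20000 nM to 150000 nM. Relative to compound 2, the estimate means an expected at least 1.6-fold lower number from compound 2 to compound 4 (0.22 log units; that floor lies within the scatter).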

Compound 4, half-maximal cytotoxic concentration: > 100000 nM
Compound 4: a limit, no number; the forecaster's own chance of this, stated with the estimate: 35%; middle value at least 1.6-fold (0.22 log units) from the limit.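

In this assay compound 4 gives > 100000 nM, a limit of the assay and not a number. Compound 2 also stands at a limit, so no step between compound 2 and compound 4 can be read: the limit of > 100000 nM in this assay, at which 2 of the 4 values shown sit.

As far as these compounds go, whether hydrogen in place of ((4-methylpiperazin-1-yl)methyl)carbonyl changes the read-out in this assay at all, and by how much, remains open.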